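Swapping a dichlorophenyl for a fluorophenyl on a sulfone

The compounds below may be only part of what the source reports. "The series", "measured", "known", "first", "only" and "open" are said of these compounds alone.

Measured compounds, each tested in a functional assay on DU-145 cells (Homo sapiens) for inhibition; a higher number here means a weaker inhibitor of growth, a lower number a stronger inhibitor of growth:
- compound 1 `O=S(=O)(/C=C/c1ccc(F)cc1)Cc1ccc(Nc2ncnc3ccccc23)cc1`: 300 nM
- compound 2 `O=S(=O)(/C=C/c1ccc(Cl)cc1Cl)Cc1ccc(Nc2ncnc3ccccc23)cc1`: 3000 nM
- compound 3 `COc1cc2ncnc(Nc3ccc(CS(=O)(=O)/C=C/c4ccc(Cl)cc4Cl)cc3)c2cc1OC`: 1400 nM

Compound 1 and compound 2 share one core and differ at a single place: 4-fluorophenyl in place of 2,4-dichlorophenyl on a double-bonded chain carbon bound to a double-bonded chain carbon. This change gave a 10-fold lower number from compound 2 to compound 1 (1.00 log units; beyond the scatter). Compound 3 carries the dichlorophenyl group of compound 2 but on a different core; how the two cores differ is not broken down here. In this assay compound 3 stands a little above compound 2 and well above compound 1.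

Compound 4 `COc1cc2ncnc(Nc3ccc(CS(=O)(=O)/C=C/c4ccc(F)cc4)cc3)c2cc1OC` is not yet measured. It is derived from compound 3 by the same change seen between compound 2 and compound 1: 4-fluorophenyl in place of 2,4-dichlorophenyl on a double-bonded chain carbon bound to a double-bonded chain carbon. Among the measured compounds shown here, the place of the change is the same in both pairs, so the one precedent is the only guide. On a different core the size of the step may not carry over exactly, so the expectation is held loosely.

For the measured compounds named here, because the one earlier instance gave a 10-fold lower number from compound 2 to compound 1 (1.00 log units; beyond the scatter), compound 4 is expected to show a step of about an 8.2-fold lower number from compound 3 to compound 4 (0.92 log units; beyond the scatter) from compound 3. The estimate for compound 4 in this assay is 170 nM, with a range from 50 nM to 600 nM.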

Compound 4, concentration for 50% growth inhibition: > 100000 nM
Compound 4: no number, only a limit; the forecaster's own chance of this, stated with the estimate: 0%; middle value at least 580-fold (2.76 log units) away from the limit.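

In this assay compound 4 gives > 100000 nM, which is a limit of the assay and not a number: the limit of > 100000 nM in this assay, at which 1 of the 4 values shown sits.

Replacing 2,4-dichlorophenyl with 4-fluorophenyl strengthened growth inhibition on one core, but on the other it weakened it, with an at least 71-fold higher number from compound 3 to compound 4 (1.85 log units; beyond the scatter), so in this series neither the size nor the direction of the change carried over from one core to the other: the same change on two cores in this assay, a 10-fold lower number (1.00 log units; beyond the scatter) from compound 2 to compound 1 and an at least 71-fold higher number (1.85 log units; beyond the scatter) from compound 3 to compound 4, at least 710-fold (2.85 log units) apart, beyond the scatter of two such steps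

From the compounds shown here alone, this does not show why the two cores part ways, and the true size of the loss remains unknown, since only a bound on it can be read; with a single pair on each core, it also says nothing about how the same change would behave on any third core.

The compounds shown leave open whether the reversal belongs to this particular pair of aryl groups or would also appear with other groups in the same place, such as a plain phenyl or a phenyl carrying an amine. They also leave open which part of the difference between the two cores goes with the reversal, as only these two cores can be compared here.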